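A few compounds are considered here, and "the series" means these few. Any claim that something is new, unique, unknown or untested is made for them only; others in the source may bear on it.

Measured compounds in a functional assay on MDA-MB-231 cells (Homo sapiens) for inhibition, read by MTT assay, with a stated time of 48 h; on this read-out higher numbers stand for weaker inhibition and lower numbers for stronger inhibition:

Compound 1 `COc1ccc(N(C)c2nc(C)nc3ccccc23)cc1C(=O)NCC[Se]C#N` gives 1250 nM.
Compound 2 `Cc1nc(N(C)c2ccc([Se]C#N)c(F)c2)c2ccccc2n1` gives 6 nM.
Compound 3 `CN(c1ccc([Se]C#N)cc1)c1nc(C2CC2)nc2ccccc12` gives 29 nM.

Compound 1 stands highest of the three numbers. Compound 3 lies well below it, a gap beyond the usual scatter, and compound 2 lies lower still, also beyond the scatter. Within the data shown here, both lower compounds carry the selenium-bearing group directly on the aromatic ring, whereas compound 1 carries it at the end of a chain attached through a substituent on the ring; no step between measured compounds isolates that point, so only the raw values can be set side by side.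

Compound 4 `COc1ccc(N(C)c2nc(C)nc3ccccc23)cc1OCCCCCC[Se]C#N` is the next compound to be measured in this assay. It differs from compound 1 in one place: a group of 10 heavy atoms (7 carbon, 1 nitrogen, 1 oxygen, 1 selenium; no ring) in place of a group of 8 heavy atoms (4 carbon, 2 nitrogen, 1 oxygen, 1 selenium; no ring), on an aromatic carbon. The replacement sits on an aromatic carbon of a six-membered aromatic ring of carbon only, ortho to a methoxy group and meta to a large group. The hydrogen-bond donor of the leaving group is lost; the selenium-bearing end is kept on a longer chain.

Among the measured compounds shown here, no measured pair anchors this change, so the expectation rests on compound 1 alone. A modest lowering of the number is expected, plausibly within the scatter, since the heavy substituted ring of compound 1 is retained; the estimated step from compound 1 to compound 4 is a 1.8-fold lower number from compound 1 to compound 4 (0.25 log units; within the scatter). Compound 4 is expected to give about 700 nM, within a range from 150 nM to 3000 nM.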

Compound 4, half-maximal inhibitory concentration: 3550 nM
Beside the measured number, compound 4's estimate is 5.1-fold (0.71 log units) below it; measured number above the stated range.
By their numbers in this assay, from the lowest: compound 2; then compound 3; then compound 1; then compound 4.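

Among these compounds, at this aromatic carbon, ortho to a methoxy group, this assay gives the first readable step, a 2.8-fold higher number from compound 1 to compound 4 (0.45 log units; beyond the scatter), so the longer selenium-bearing chain without a hydrogen-bond donor brings no gain over the group of compound 1. The two groups differ at once in length, in the hydrogen-bond donor and in the double bond outside the ring, and this single step cannot separate those differences. Nothing measured here bears on the reason for the step.

Still open, as far as these compounds go, is whether a shorter chain on the same oxygen link would lower the number or raise it further. Also open, from the compounds shown here alone, is how an amine in place of the selenium-bearing end would read, and compound 2 and compound 3 differ from compound 4 in too many places to settle either question.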